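Shortening the chain and freeing the acid on a shared core

A few compounds are considered here, and "the series" means these few. Any claim that something is new, unique, unknown or untested is made for them only; others in the source may bear on it.

Compound 1 `COC(=O)CCCCCOc1cc(-c2ccccc2)cc(-c2ccccc2)n1` is the weakest of three measured compounds in an assay for binding affinity to leukotriene B4 receptor 1 (Homo sapiens) (a higher number here means a weaker inhibitor, a lower number a stronger inhibitor), where compound 1 gives 100 nM. Compound 2 `O=C(O)CCCCCOc1cc(-c2ccccc2)cc(-c2ccc(F)cc2)n1` sits nearest, and in this assay compound 2 gives 30 nM, a gap beyond the scatter. Compound 3 `CC(CCCCOc1cc(-c2ccccc2)cc(-c2ccccc2F)n1)C(=O)O` lies furthest away, and in this assay compound 3 gives 18 nM, also beyond the scatter. Among the measured compounds shown here, no step between compounds that differ in a single place is available, so the move to compound 4 `O=C(O)CCCCOc1cc(-c2ccccc2)cc(-c2ccccc2)n1` rests on the change itself: carboxy in place of (methoxycarbonyl)methyl on a saturated chain carbon, four bonds along the chain from an oxygen on an aromatic ring. Both compounds that give lower numbers than compound 1 carry a carboxy group rather than a chain ending in a methoxycarbonyl group, so compound 4 is expected to move in the same direction, towards a lower number in this assay, with a step of modest size beyond the scatter, a 2.9-fold lower number from compound 1 to compound 4 (0.46 log units; beyond the scatter). Compound 4 is therefore expected to give about 35 nM in this assay, with a range from 12 nM to 100 nM.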

Compound 4, half-maximal inhibitory concentration: 300 nM
For compound 4 the middle estimate is 8.6-fold (0.93 log units) below the measured one; measured number outside the range, above it.
By their numbers in this assay, from the lowest: compounds 3 and 2 (each within the scatter of the next); then compound 1; then compound 4.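

In this assay, among the compounds shown here, carboxy in place of (methoxycarbonyl)methyl, on a saturated chain carbon four bonds along the chain from an oxygen on an aromatic ring, brings a 3.0-fold higher number from compound 1 to compound 4 (0.48 log units; beyond the scatter) on an otherwise unchanged core, the first change in a single place here, and it makes the inhibitor weaker, so a carboxy group at this place does not by itself give a lower number. The same difference reads as 4-(methoxycarbonyl)butyl to 3-carboxypropyl, so end group and chain length change together and this step cannot separate them. Nothing available bears on why the number rises.

Open, from the compounds shown here alone, is how a methyl ester on the shorter chain, or a carboxylic acid on the longer chain, would read on the core of compound 1. Also open, going by these compounds, is how an amide or a tetrazole at the chain end would compare.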